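Swapping an aryl thioether on a shared core

The source may hold more compounds than are shown below. What is called first, only, known or untested is meant among the compounds shown, and "the series" means these compounds.

Of the compounds shown here, two built on the same core have been tested for their power to stop the growth of a lung cancer cell line, and a third is next in line. In a functional assay on HOP-62 cells (Homo sapiens) for inhibition, read by sulforhodamine B assay, with a stated time of 48 h (on this read-out higher numbers stand for weaker inhibition of growth and lower numbers for stronger inhibition of growth), compound 1, with the structure `Nc1cc(N)c2nc(-c3ccccc3)c(NCc3ccc(F)cc3)nc2c1`, gives < 100000 nM, which is a limit of the assay and not a number. In this assay compound 2, with the structure `COc1ccc(Sc2nc3cc(N)cc(N)c3nc2-c2ccccc2)cc1`, likewise gives < 100000 nM, again a limit rather than a number. Among the compounds with values here, the only step between measured compounds, a step that the two limits leave unreadable from compound 1 to compound 2, is therefore of unknown size, because of the limit of < 100000 nM in this assay, at which 2 of the 2 values shown sit.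

Compound 3, with the structure `Nc1cc(N)c2nc(-c3ccccc3)c(Sc3ccc(Cl)c(Cl)c3)nc2c1`, differs from compound 2 by 3,4-dichlorophenyl in place of 4-methoxyphenyl on a sulfur. Within the data shown here, no measured step reads on this change, and the two limits give no anchor beyond the top of the measurable window. Compound 3 is expected to sit near that same ceiling, with an estimated 60000 nM (range 15000 nM to 100000 nM), which would mean an expected step that the limit leaves unreadable from compound 2 to compound 3 from compound 2 to compound 3, though a limit rather than a number remains the likeliest outcome.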

Compound 3, concentration for total growth inhibition: 77600 nM
The estimate for compound 3 lay 1.3-fold (0.11 log units) below the measured number; the measured number falls inside the stated range.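

No size can be given for the step to compound 3 from either compound 2 or compound 1, because the values of compound 1 and compound 2 are limits and not numbers: the limit of < 100000 nM in this assay, at which 2 of the 3 values shown sit.

The compounds shown leave open whether 3,4-dichlorophenyl in place of 4-methoxyphenyl on a sulfur changes growth inhibition at all.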